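Swapping an aromatic ring for a saturated one at the chain end

This account rests on a few compounds, and the source may have more. Where it says the series, first, only, none or still open, it means among the compounds named here.

Compound 1 `COc1cc(NC(C)CCCNC(=O)NCc2ccncc2)c2ncccc2c1` carries a (pyridin-4-yl)methyl group on the outer urea nitrogen of a shared core; in a functional assay on MCF7 cells (Homo sapiens), read by MTT assay, with a stated time of 72 h (on this read-out lower numbers stand for stronger inhibition and higher numbers for weaker inhibition), compound 1 gives 30000 nM. Two close relatives have been measured in the same way. Compound 2 `COc1cc(NC(C)CCCNC(=O)NCc2ccccc2)c2ncccc2c1` gives 25000 nM, and compound 3 `COc1cc(NC(C)CCCNC(=O)NC2CCCCC2)c2ncccc2c1` gives 41000 nM. Among these three numbers compound 1 stands second highest, and every pairwise step lies within the scatter: a 1.2-fold lower number from compound 1 to compound 2 (0.08 log units; within the scatter), a 1.4-fold higher number from compound 1 to compound 3 (0.14 log units; within the scatter) and a 1.6-fold higher number from compound 2 to compound 3 (0.21 log units; within the scatter).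

Compound 4 `COc1cc(NC(C)CCCNC(=O)NCC2CCCCC2)c2ncccc2c1` has not yet been measured. It differs from compound 1 in one place: cyclohexyl in place of pyridin-4-yl on a saturated chain carbon bound to an amide-type nitrogen. Two of the measured steps bear on this change. The step of a 1.2-fold lower number from compound 1 to compound 2 (0.08 log units; within the scatter) replaces the same aromatic ring by a carbocyclic aromatic one at the same chain carbon, and the step of a 1.4-fold higher number from compound 1 to compound 3 (0.14 log units; within the scatter) brings in the same cyclohexyl ring, though one bond closer to the amide-type nitrogen. Both stayed inside the scatter, and the move from compound 2 to compound 3 did too. Nothing here points to a shift beyond the scatter in this assay for compound 4.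

Compound 4 is therefore expected to give about 38000 nM, with a likely range from 15000 nM to 95000 nM. That expectation corresponds to a step of a 1.3-fold higher number from compound 1 to compound 4 (0.10 log units; within the scatter).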

Compound 4, half-maximal inhibitory concentration: 61000 nM
For compound 4 the middle estimate is 1.6-fold (0.21 log units) below the measured one; the measured number falls inside the stated range.
By their numbers in this assay, from the lowest: compounds 2, 1, 3 and 4 (each within the scatter of the next, the first and the last beyond it).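

In this assay, cyclohexyl in place of pyridin-4-yl on a saturated chain carbon bound to an amide-type nitrogen gives a 2.0-fold higher number from compound 1 to compound 4 (0.31 log units; beyond the scatter), and cyclohexyl in place of phenyl at the same place gives a 2.4-fold higher number from compound 2 to compound 4 (0.39 log units; beyond the scatter). Unlike the steps among compounds 1, 2 and 3, both of these pass the scatter, though only modestly, and since compound 2 and compound 4 both lack a ring nitrogen, the second step shows that a non-aromatic ring at this carbon can shift the number without any change in ring nitrogen count. By contrast, cyclohexylmethyl in place of cyclohexyl on an amide-type nitrogen stays inside the scatter, at a 1.5-fold higher number from compound 3 to compound 4 (0.17 log units; within the scatter), and nothing at hand gives a reason for any of these steps.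

From the compounds shown here alone, it remains open whether piperidin-4-yl, a saturated ring that keeps a nitrogen, would at this chain carbon read like pyridin-4-yl or like cyclohexyl. Going by these compounds, it is equally open whether a longer chain between the cyclohexyl ring and the amide-type nitrogen, or a carboxylic acid on that ring, would move the number further from that of compound 1.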